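This account rests on a few compounds, and the source may have more. Where it says the series, first, only, none or still open, it means among the compounds named here.

Measured compounds:
compound 1, `C#CCCCn1c(Cc2cc(OC)c(OC)c(OC)c2)nc2c(N)nc(F)nc21`, 11000 nM
compound 2, `C#CCCCn1c(Cc2cc(OC)c(OC)c(OC)c2)nc2c(N)ncnc21`, 24000 nM
compound 3, `COCCn1c(Cc2cc(OC)c(OC)c(OC)c2)nc2c(N)ncnc21`, 64600 nM

Three compounds were tested in a functional assay on MCF7 cells (Homo sapiens) for antiproliferative activity; a lower number here means a stronger inhibitor, a higher number a weaker inhibitor. Compound 2 is the reference point for two changes. Compound 1 differs from compound 2 by fluoro in place of hydrogen on an aromatic carbon, and this gave a 2.2-fold lower number from compound 2 to compound 1 (0.34 log units; beyond the scatter). Compound 3 differs from compound 2 by methoxy in place of propargyl on a saturated chain carbon, two bonds along the chain from an aromatic nitrogen, and this gave a 2.7-fold higher number from compound 2 to compound 3 (0.43 log units; beyond the scatter). Compound 3 thus has the highest number of the three, and its gap to compound 1, the compound with the lowest number, is beyond the scatter.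

Compound 4, `COCCn1c(Cc2cc(OC)c(OC)c(OC)c2)nc2c(N)nc(F)nc21`, has not yet been measured in this assay. It differs from compound 3 by fluoro in place of hydrogen on an aromatic carbon. Among the measured compounds shown here, this is the same change as the one from compound 2 to compound 1, and it sits at the same place on the shared core; the two cores differ only by methoxy in place of propargyl on a saturated chain carbon, two bonds along the chain from an aromatic nitrogen. Compound 3 and compound 4 form a second pair for the fluoro-for-hydrogen change, and with one prior example nothing more than a rough transfer can be claimed.

For compound 4 in this assay the expected step is a 2.2-fold lower number from compound 3 to compound 4 (0.33 log units; beyond the scatter), because the earlier example gave a 2.2-fold lower number from compound 2 to compound 1 (0.34 log units; beyond the scatter) and compound 3 starts from 64600 nM. On that basis compound 4 is estimated at 30000 nM, with a likely range from 12000 nM to 70000 nM.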

Compound 4, half-maximal inhibitory concentration: 64600 nM
Estimate against measurement, compound 4: 2.2-fold (0.33 log units) below; measured number inside the range.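

In this assay, fluoro in place of hydrogen on the aromatic carbon gave no change at the digits printed from compound 3 to compound 4 (within the scatter), yet this result and the earlier one on the core of compound 2 cannot be told apart: the same change on two cores in this assay, a 2.2-fold lower number (0.34 log units; beyond the scatter) from compound 2 to compound 1 and no change at the digits printed (within the scatter) from compound 3 to compound 4, 2.2-fold (0.34 log units) apart, within the scatter of two such steps. Seen from the other side of the same square, methoxy in place of propargyl gave a 5.9-fold higher number from compound 1 to compound 4 (0.77 log units; beyond the scatter) on the fluorinated core, and this step likewise cannot be separated from its counterpart on the core without fluoro: the same change on two cores in this assay, a 2.7-fold higher number (0.43 log units; beyond the scatter) from compound 2 to compound 3 and a 5.9-fold higher number (0.77 log units; beyond the scatter) from compound 1 to compound 4, 2.2-fold (0.34 log units) apart, within the scatter of two such steps. The two cores therefore give no evidence that the effect of either change depends on the core, but they do not show that the fluoro change carries over reliably either, since it lowered the number beyond the scatter in one pair, stayed within the scatter in the other, and two pairs cannot fix the size of a step.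

The compounds shown leave open whether chloro or an amino group on the same aromatic carbon, between two ring nitrogen atoms, would behave as fluoro does. They also leave open how the fluoro change would fare on a core carrying a longer chain or a chain ending in an amine on the aromatic nitrogen.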